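A few compounds are considered here, and "the series" means these few. Any claim that something is new, unique, unknown or untested is made for them only; others in the source may bear on it.

Measured so far in a functional assay on HL-60 cells (Homo sapiens) for inhibition, read by CCK-8 assay, with a stated time of 48 h, tested at 20 uM; on this read-out higher numbers stand for more inhibition of growth at the one concentration tested and lower numbers for less inhibition of growth:
Compound 1, `Cc1ccc(S(=O)(=O)Oc2ccccc2/C=C(\C#N)C(=O)Nc2nnc(Cc3ccccc3)s2)cc1`: compound 1 gives 16%.
Compound 2, `COc1ccc(S(=O)(=O)Oc2ccccc2/C=C(\C#N)C(=O)Nc2nnc(Cc3ccccc3)s2)cc1`: compound 2 gives 100%.
Compound 3, `Cc1ccc(S(=O)(=O)Oc2ccccc2/C=C(\C#N)C(=O)Nc2nnc(Cc3ccc(Cl)cc3)s2)cc1`: compound 3 gives 15%.

Compound 4, `COc1ccc(S(=O)(=O)Oc2ccccc2/C=C(\C#N)C(=O)Nc2nnc(Cc3ccc(Cl)cc3)s2)cc1`, has not yet been measured. It differs from compound 3 by methoxy in place of methyl on an aromatic carbon. The same change, (methoxy in place of methyl on an aromatic carbon), was made from compound 1 to compound 2, where it gave a number 84 percentage points higher from compound 1 to compound 2 (beyond the scatter). The two cores differ by chloro in place of hydrogen on an aromatic carbon, a difference that made a number 1 percentage points lower from compound 1 to compound 3 (within the scatter). Going by the values given here, the place of the change is described in the same words for both pairs, so it is the same change, seen once so far; no other pair shows whether it repeats. Because a number 84 percentage points higher from compound 1 to compound 2 (beyond the scatter) was large, compound 4 is expected to show a step of a number 70 percentage points higher from compound 3 to compound 4 (beyond the scatter). Compound 4 is estimated at 85%, between 40% and 100%.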

Compound 4, percent growth inhibition at one concentration: 99%
Compound 4: the middle estimate sits 14 percentage points below what was measured, within the range that was stated.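

In this assay, methoxy in place of methyl on an aromatic carbon gave a number 84 percentage points higher from compound 3 to compound 4 (beyond the scatter), and this matches the step on the core of compound 1: the same change on two cores in this assay, a number 84 percentage points higher (beyond the scatter) from compound 1 to compound 2 and a number 84 percentage points higher (beyond the scatter) from compound 3 to compound 4, 0 percentage points apart, within the scatter of two such steps. Chloro in place of hydrogen on an aromatic carbon gave a number 1 percentage points lower from compound 2 to compound 4 (within the scatter), which also matches the earlier step: the same change on two cores in this assay, a number 1 percentage points lower (within the scatter) from compound 1 to compound 3 and a number 1 percentage points lower (within the scatter) from compound 2 to compound 4, 0 percentage points apart, within the scatter of two such steps. The two changes therefore combined without interfering across these four compounds, but this does not show that the methoxy step carries to cores that differ in any other way, and a single concentration with compound 2 and compound 4 both close to the top of the scale cannot separate their potencies.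

The compounds shown leave open whether an ethoxy group, a hydroxyl or an amine in place of the methoxy would give a similar step. They also leave open whether the step would hold with a group other than chloro on the benzyl ring.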